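Swapping cyano for formyl: what the limits allow

A few compounds are considered here, and "the series" means these few. Any claim that something is new, unique, unknown or untested is made for them only; others in the source may bear on it.

Compound 1 `O=[N+]([O-])c1c(CS(=O)(=O)c2ccccc2)nc2c(-c3ccc(Cl)cc3)cc(Cl)cn12`: > 3900 nM
Compound 2 `N#Cc1ccc(-c2cc(Cl)cn3c([N+](=O)[O-])c(CS(=O)(=O)c4ccccc4)nc23)cc1`: > 3900 nM

Both entries come from an ADME assay on HepG2 cells (Homo sapiens) for cytotoxicity, read by MTT assay, with a stated time of 72 h (on this read-out lower numbers stand for higher toxicity in this test and higher numbers for lower toxicity in this test), and each is a limit, not a number. Compound 2 stands at the limit of > 3900 nM in this assay, at which 2 of the 2 values shown sit. Compound 3 `O=Cc1ccc(-c2cc(Cl)cn3c([N+](=O)[O-])c(CS(=O)(=O)c4ccccc4)nc23)cc1` carries formyl in place of cyano on an aromatic carbon. For the measured compounds named here, the only measured step, a step that the two limits leave unreadable from compound 1 to compound 2, offers no size to carry over, so no shift beyond the usual scatter is expected in this assay. The expected change is a step that the limit leaves unreadable from compound 2 to compound 3. For compound 3 the estimated value is 4500 nM, with an expected range from 2000 nM to 12000 nM.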

Compound 3, half-maximal cytotoxic concentration: > 31200 nM
Compound 3 gave a limit, no number (the forecaster's own chance of this, stated with the estimate: 70%); at least 6.9-fold (0.84 log units) between middle value and limit.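

No step can be read between compound 1, compound 2 and compound 3, since each gives only a limit, not a number. From the compounds shown here alone, their actual values stay open, as does whether chloro, cyano or formyl changes the toxicity in this test at all.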